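Isopropenyl for methyl on the aryl piperazine of compound 2

This account rests on a few compounds, and the source may have more. Where it says the series, first, only, none or still open, it means among the compounds named here.

Working notes on the series. Compound 1 `Cc1nc(-c2cccc(O)c2)c(C(=O)N2CCN(c3cccc(Cl)c3)CC2)o1` gives 105 nM in a functional assay on HL-60 cells (Homo sapiens) for inhibition, read by MTT assay, with a stated time of 72 h; on this read-out higher numbers stand for weaker inhibition and lower numbers for stronger inhibition. Compound 3 `CCc1nc(-c2cccc(F)c2)c(C(=O)N2CCN(c3cccc(Cl)c3)CC2)o1` gives 317 nM in this assay. Within the data shown here, compound 2 `Cc1ccc(N2CCN(C(=O)c3oc(C)nc3-c3ccccc3)CC2)cc1` differs from both in the aryl group on the five-membered core and in the aryl group on the piperazine nitrogen; no single-point step connects it to compound 1 or compound 3, so only its own reading is noted. In this assay compound 2 gives > 1000 nM, which is a limit of the assay rather than a number. Compound 2 therefore sits at the limit of > 1000 nM in this assay, at which 1 of the 3 values shown sits, and where it stands among the measured compounds cannot be fixed more closely than that.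

Compound 4 `C=C(C)c1ccc(N2CCN(C(=O)c3oc(C)nc3-c3ccccc3)CC2)cc1` is the next step from compound 2: 1-methylethenyl in place of methyl on an aromatic carbon. The group that enters is a three-carbon unit with one double bond outside the aromatic rings, placed on an aromatic carbon of a six-membered aromatic ring of carbon only, para to a large group. Among the measured compounds shown here, no measured pair of compounds shows the effect of this change, so no size can be read from the data. With compound 2 already at the limit, compound 4 is expected to stay weak, and the step that the limit leaves unreadable from compound 2 to compound 4 is expected to be none beyond the scatter. For compound 4 the estimate in this assay is 1500 nM, between 400 nM and 6000 nM, with a fair chance that only a limit is reported again.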

Compound 4, half-maximal inhibitory concentration: "not active" (no number reported)
No number was reported for compound 4; no gap can be computed for the estimate.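

In this assay compound 2 gives > 1000 nM, a limit of the assay. Among these compounds, compound 4 is reported as not active, with no number, so no step from compound 2 to compound 4 can be read. The compounds shown leave open what 1-methylethenyl in place of methyl does where the starting compound has a numerical value.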